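What an isopropoxy group may do to compound 3

A few compounds are considered here, and "the series" means these few. Any claim that something is new, unique, unknown or untested is made for them only; others in the source may bear on it.

- compound 1 (`COc1ccc(C2=C(c3cc(OC)c(OC)c(OC)c3)C(=O)C(OC(C)=O)C2)cc1OC(C)C`): > 100 ug/mL, a limit
- compound 2 (`COc1ccc(C2=C(c3cc(OC)c(OC)c(OC)c3)C(=O)C(O)C2)cc1`): < 1 ug/mL, a limit
- compound 3 (`COc1ccc(C2=C(c3cc(OC)c(OC)c(OC)c3)C(=O)C(O[SiH2]C(C)(C)C)C2)cc1`): 16 ug/mL

Among the compounds with values here, in an ADME assay on ECV-304 cells (Homo sapiens) for cytotoxicity, read by MTT assay, with a stated time of 72 h (on this read-out higher numbers stand for weaker inhibition and lower numbers for stronger inhibition), compound 3 holds the only true number, 16 ug/mL. The other two values are limits. Compound 4 (`COc1ccc(C2=C(c3cc(OC)c(OC)c(OC)c3)C(=O)C(O[SiH2]C(C)(C)C)C2)cc1OC(C)C`) differs from it as follows: isopropoxy in place of hydrogen on an aromatic carbon. Within the data shown here, the one measured step, an at least 16-fold higher number from compound 2 to compound 3 (1.20 log units; beyond the scatter), lies elsewhere on the molecule, so it shows only that a single change can move this number far. Among the measured compounds shown here, compound 1, the only measured compound with the isopropoxy group, sits at a limit, > 100 ug/mL. It also differs from compound 3 elsewhere, so this guide is weak. The expected change is a 2.8-fold higher number from compound 3 to compound 4 (0.45 log units; beyond the scatter), towards weaker inhibition. For compound 4 the estimated value is 45 ug/mL, with an expected range from 12 ug/mL to 150 ug/mL.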

Compound 4, half-maximal inhibitory concentration: > 100 ug/mL
Compound 4: a limit, no number; the forecaster's own chance of this, stated with the estimate: 35%; middle value at least 2.2-fold (0.34 log units) away from the limit.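

Isopropoxy in place of hydrogen on this aromatic carbon, ortho to a methoxy group, gives an at least 6.2-fold higher number from compound 3 to compound 4 (0.79 log units; beyond the scatter) in this assay, with nothing else on the molecule changed. This one change alone therefore weakens inhibition beyond the scatter, which compound 1 could not show, since it also differs elsewhere. How far the number really rises stays unknown, and the step between compound 1 and compound 4 cannot be read, since both are limits: the limit of > 100 ug/mL in this assay, at which 2 of the 4 values shown sit.

Open, from the compounds shown here alone, is what an ethoxy group or an amine would do at this position. Also open, going by these compounds, is whether isopropoxy has the same effect on the free hydroxyl of compound 2.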